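The source may report more compounds than this note shows. Statements on the series, on what has been measured and on what is new or still open speak of the compounds shown alone.

The measured compounds:
compound 1 `O=C(O)CCc1ccc(NCc2ccccc2)cc1`, 759 nM;
compound 2 `O=C(O)CCc1ccc(OCc2ccc(Br)cc2)cc1`, 550 nM;
compound 3 `O=C(O)CCc1ccc(OCc2ccccc2Br)cc1`, 447 nM.

All three values come from a functional assay on 1321-N1 cells for agonist activity at Free fatty acid receptor 1 (Homo sapiens), read by calcium flux; on this read-out higher numbers stand for an effect only at larger amounts of compound and lower numbers for an effect already at smaller amounts. Compound 1 stands at the highest of the three numbers, yet its gaps to compound 2 and to compound 3 both lie within the usual scatter, so the three cannot be told apart on these data. Compound 4 `O=C(O)CCc1ccc(NCc2cccc(Br)c2)cc1` differs from compound 1 by bromo in place of hydrogen on an aromatic carbon. Going by the values given here, no measured pair shows this exact step. Compound 2 and compound 3 each carry bromine and give numbers close to that of compound 1, which suggests that bromine changes little here. For compound 4 in this assay a small step toward lower numbers, probably no larger than the scatter, is expected: a 1.5-fold lower number from compound 1 to compound 4 (0.18 log units; within the scatter). The estimate for compound 4 is 500 nM, with a range from 200 nM to 1500 nM.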

Compound 4, half-maximal effective concentration: 174 nM
Estimate against measurement, compound 4: 2.9-fold (0.46 log units) above; the measured number lies below the stated range.
By their numbers in this assay, from the lowest: compound 4; then compounds 3, 2 and 1 (each within the scatter of the next).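

In this assay, bromo in place of hydrogen on this aromatic carbon, meta to a large group, gives a 4.4-fold lower number from compound 1 to compound 4 (0.64 log units; beyond the scatter) for the addition of a single heavy atom. Going by these compounds alone, this is the first pair that isolates one change, and it shows that this position on the core of compound 1 responds to bromo. Nothing available explains the size of this step.

On these data alone, it remains open whether chloro, methyl or methoxy on the same carbon would give a similar step. Also open, as far as these compounds go, is whether bromo on the ring's other carbons would do so in the core of compound 1.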